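From Fluoro to Chloro: Estimating Compound 4

The source may hold more compounds than are shown below. What is called first, only, known or untested is meant among the compounds shown, and "the series" means these compounds.

Compound 1 `Cc1ccc([C@@H](C)Oc2cc3onc(CCC(=O)O)c3cc2Cl)nc1`: 1.59 nM
Compound 2 `O=C(O)CCn1c(=O)oc2cc(OCc3ccccn3)c(Cl)cc21`: 5010 nM
Compound 3 `C[C@@H](Oc1cc2onc(CCC(=O)O)c2cc1Cl)c1ccc(F)cn1`: 31.6 nM

In an assay on HEK293 cells for inhibition of kynurenine 3-monooxygenase (Homo sapiens), read by LC-MS, with a stated time of 20 h (on this read-out lower numbers stand for stronger inhibition and higher numbers for weaker inhibition), compound 3 stands second highest of the three measured numbers, with compound 1 giving the lowest value and compound 2 the highest. Compound 4 `C[C@@H](Oc1cc2onc(CCC(=O)O)c2cc1Cl)c1ccc(Cl)cn1` differs from compound 3 by chloro in place of fluoro on an aromatic carbon. Going by the values given here, only one measured step touches this position: a 20-fold higher number from compound 1 to compound 3 (1.30 log units; beyond the scatter). That step shows the fluoro-bearing compound 3 giving a much higher number than the methyl-bearing compound 1. A chloro group, the third substituent tried at this site, is expected to land somewhere between, so the estimated step is a 5.3-fold lower number from compound 3 to compound 4 (0.72 log units; beyond the scatter). Compound 4 is therefore estimated at 6 nM, with a range from 1.5 nM to 25 nM.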

Compound 4, half-maximal inhibitory concentration in the kynurenine 3-monooxygenase assay: 3.98 nM
For compound 4 the middle estimate is 1.5-fold (0.18 log units) above the measured one, within the range that was stated.
By their numbers in the kynurenine 3-monooxygenase assay, from the lowest: compound 1; then compound 4; then compound 3; then compound 2.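

In the kynurenine 3-monooxygenase assay, this position proves sensitive to the choice of halogen, with a 7.9-fold lower number from compound 3 to compound 4 (0.90 log units; beyond the scatter) for chloro in place of fluoro. Chloro recovers much of the ground lost with fluoro, yet methyl still gives the lowest number of the three groups, with a 2.5-fold higher number from compound 1 to compound 4 (0.40 log units; beyond the scatter). In a physicochemical assay for lipophilicity, read by HPLC, at pH 7.4 (a lower number here means a more polar compound, a higher number a more lipophilic compound), compound 3 gives 2.47 and compound 4 gives 2.91, so the same change also gives a more lipophilic compound: the measured distribution coefficient of compound 3, 2.47, and of compound 4, 2.91, a number 0.44 log units higher (beyond the scatter)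

A single pair cannot separate the stronger inhibition from this rise in lipophilicity. Going by these compounds, how a nitrile or a methoxy group would compare at this position remains open.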